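The source may hold more compounds than are shown below. What is called first, only, known or untested is meant among the compounds shown, and "the series" means these compounds.

Measured so far in a functional assay on KBVIN cells (Homo sapiens) for antiproliferative activity, read by sulforhodamine B assay, with a stated time of 3 days; a higher number here means a weaker inhibitor of growth, a lower number a stronger inhibitor of growth:
- compound 1 `CN(C)c1ccc(C(=O)Nc2cccc(Nc3ncc(F)c(Nc4ccc(F)cc4)n3)c2)cc1` gives > 10000 nM
- compound 2 `COCC(=O)Nc1cccc(Nc2ncc(F)c(Nc3ccc(F)cc3)n2)c1` gives 3940 nM

The value of compound 1 is a limit and not a number. Among the compounds with values here, that leaves compound 2 (3940 nM) as the only actual number. The next compound is compound 3 (`CN(C)CC(=O)Nc1cccc(Nc2ncc(F)c(Nc3ccc(F)cc3)n2)c1`), reached by the change dimethylamino in place of methoxy on a saturated chain carbon bound to a carbonyl carbon that puts dimethylamino in place of methoxy on a saturated chain carbon bound to a carbonyl carbon. Within the data shown here, the only measured step (an at least 2.5-fold lower number from compound 1 to compound 2 (0.40 log units; beyond the scatter)) is a different exchange, methoxymethyl in place of 4-(dimethylamino)phenyl on a carbonyl carbon. It rests on the limit of > 10000 nM in this assay, at which 1 of the 2 values shown sits, and bears only loosely on this change. No direct comparison of methoxy and dimethylamino has been measured, so no step beyond the scatter is expected in this assay in either direction. The expected step is a 1.3-fold lower number from compound 2 to compound 3 (0.12 log units; within the scatter) on this estimate. Compound 3 is estimated at 3000 nM (range 800 nM to 10000 nM).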

Compound 3, concentration for 50% growth inhibition: 1810 nM
Beside the measured number, compound 3's estimate is 1.7-fold (0.22 log units) above it; the measured number falls inside the stated range.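

In this assay, the exchange on a saturated chain carbon bound to a carbonyl carbon now has a direct reading: dimethylamino in place of methoxy gives a 2.2-fold lower number from compound 2 to compound 3 (0.34 log units; beyond the scatter). Compound 1 and compound 3 both carry dimethylamino, yet the change of the group on the carbonyl carbon gives an at least 5.5-fold lower number from compound 1 to compound 3 (0.74 log units; beyond the scatter), so the presence of dimethylamino alone does not set the number in this series. Compound 1 gives > 10000 nM, a limit and not a number, so this second step has no fixed size: the limit of > 10000 nM in this assay, at which 1 of the 3 values shown sits.

Whether the lower number is specific to dimethylamino remains open, as the compounds shown include no primary amine, pyrrolidine or morpholine on the same chain carbon. Also open, from the compounds shown here alone, is how a longer chain between the carbonyl and the amine would read.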